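Hydroxyphenyl for dimethoxyphenyl on the biaryl amide: cytotoxicity notes

A few compounds are considered here, and "the series" means these few. Any claim that something is new, unique, unknown or untested is made for them only; others in the source may bear on it.

The series shares one core, shown in compound 1 `CCOC(=O)CCCCCOc1cccc(CN(C(=O)c2ccccc2)C(C)C)c1`. In an ADME assay on HepG2 cells (Homo sapiens) for cytotoxicity, read by CellTiter-Glo and resazurin assay, with a stated time of 72 h (a higher number here means that more compound is needed for the effect, a lower number that less compound is needed), compound 1 reaches only a limit, > 26000 nM. Compound 2 `CCOC(=O)CCCCCOc1cccc(CN(C(=O)c2ccc(-c3cccc(OCC)c3)cc2)C(C)C)c1` carries a 3-ethoxyphenyl where compound 1 has hydrogen. In this assay compound 2 also reaches only a limit, > 22300 nM. Compound 3 `CCOC(=O)CCCCCOc1cccc(CN(C(=O)c2ccc(-c3cc(OC)cc(OC)c3)cc2)C(C)C)c1` carries a 3,5-dimethoxyphenyl at that position. In this assay compound 3 again reaches only a limit, > 26000 nM. The steps are therefore unreadable: a step that the two limits leave unreadable from compound 1 to compound 2, a step that the two limits leave unreadable from compound 1 to compound 3 and a step that the two limits leave unreadable from compound 2 to compound 3. Compound 3 thus stands at the limit of > 26000 nM in this assay, at which 2 of the 3 values shown sit, while the remaining value sits at the limit of > 22300 nM in this assay, at which 1 of the 3 values shown sits; no number separates the three.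

Compound 4 `CCOC(=O)CCCCCOc1cccc(CN(C(=O)c2ccc(-c3cccc(O)c3)cc2)C(C)C)c1` differs from compound 3 by 3-hydroxyphenyl in place of 3,5-dimethoxyphenyl on an aromatic carbon. Within the data shown here, the steps that bear on this position, from compound 1 to compound 3 and from compound 2 to compound 3, gave no readable size, and no measured step shows any compound leaving the limit. Compound 4 is therefore expected to give 26000 nM, with a range from 13000 nM to 60000 nM. That estimate means a number no higher from compound 3 to compound 4 (the limit leaves the size open), no step beyond the scatter, and most likely another limit rather than a number.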

Compound 4, half-maximal effective concentration: > 26000 nM
Compound 4: no number, only a limit; the forecaster's own chance of this, stated with the estimate: 85%; the middle value sits exactly at the limit.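

In this assay compound 4 gives > 26000 nM, which is a limit and not a number. Its steps from compound 1, compound 2 and compound 3 therefore cannot be read. The compounds shown leave open where any half-maximal effective concentration lies, and whether the groups on the biaryl amide differ at all in this assay.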